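Two chlorines on the benzyl ether of compound 1

A few compounds are considered here, and "the series" means these few. Any claim that something is new, unique, unknown or untested is made for them only; others in the source may bear on it.

Compound 1 `Cc1cc(C(=O)O)nn1Cc1cc(Br)ccc1OCc1ccccc1` gives 15.1 nM in a functional assay on CHO-K1 cells for antagonist activity at prostaglandin E2 receptor EP1 subtype (Homo sapiens), read by FLIPR (a higher number here means a weaker inhibitor, a lower number a stronger inhibitor), the lowest of the two numbers measured. Compound 3 `CCCCc1cc(C(=O)O)nn1Cc1cc(Br)ccc1OCc1ccccc1` gives 977 nM in this assay, and the step of a 65-fold higher number from compound 1 to compound 3 (1.81 log units; beyond the scatter) is large. For compound 2 `CC(=O)Nc1cc(C(=O)O)nn1Cc1cc(Br)ccc1OCc1ccccc1` the value < 2000 nM in this assay is a limit of the assay, not a number. Compound 4 `Cc1cc(C(=O)O)nn1Cc1cc(Br)ccc1OCc1ccc(Cl)cc1Cl` differs from compound 1 by 2,4-dichlorophenyl in place of phenyl on a saturated chain carbon bound to an oxygen on an aromatic ring. The measured steps of a 65-fold higher number from compound 1 to compound 3 (1.81 log units; beyond the scatter) and a step that the limit leaves unreadable from compound 1 to compound 2 both alter the group on the shared core, not the benzyl ether, so neither bears directly on this change. The step of a 1.0-fold lower number from compound 1 to compound 4 (0.00 log units; within the scatter) is therefore expected to stay within the scatter. The estimate for compound 4 in this assay is 15 nM, between 4 nM and 60 nM.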

Compound 4, inhibition constant: 0.49 nM
The estimate for compound 4 lay 31-fold (1.49 log units) above the measured number, outside the stated range (below it).
By their numbers in this assay, from the lowest: compound 4; then compound 1; then compound 3.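

In this assay, the benzyl ether proves a position that answers strongly to substitution: the change to 2,4-dichlorobenzyl gives a 31-fold lower number from compound 1 to compound 4 (1.49 log units; beyond the scatter), a large step. The earlier readable step, a 65-fold higher number from compound 1 to compound 3 (1.81 log units; beyond the scatter), altered the group on the shared core and ran towards a higher number, so this is the first change shown that lowers the number.

As far as these compounds go, whether a single chlorine, or a fluorine or a methoxy group on that ring, would give a similar step remains open. Nothing at hand accounts for the size of this step.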